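Replacing Phenyl with Pyridin-4-yl in Compound 1

A few compounds are considered here, and "the series" means these few. Any claim that something is new, unique, unknown or untested is made for them only; others in the source may bear on it.

In a functional assay for inhibition, with Homo sapiens as the target (on this read-out higher numbers stand for weaker inhibition and lower numbers for stronger inhibition), compound 1 `CCOc1ccccc1C(=O)/C=C/c1ccccc1` gives 609 nM and compound 2 `O=C(/C=C/c1ccccc1)c1ccccc1C(F)(F)F` gives 748 nM, two values within the scatter of each other. Compound 3 `CCOc1ccccc1C(=O)/C=C/c1ccncc1` differs from compound 1 by pyridin-4-yl in place of phenyl on a double-bonded chain carbon bound to a double-bonded chain carbon, with pyridin-4-yl in place of phenyl on a double-bonded chain carbon bound to a double-bonded chain carbon. Going by the values given here, the one measured step, a 1.2-fold higher number from compound 1 to compound 2 (0.09 log units; within the scatter), swaps ethoxy for trifluoromethyl on an aromatic carbon and leaves the phenyl untouched, so it offers only weak guidance. No step beyond the scatter is therefore expected in this assay, and the estimated change is a 1.3-fold higher number from compound 1 to compound 3 (0.12 log units; within the scatter). For compound 3, the estimated value is 800 nM, with an expected range of 250 nM to 2500 nM.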

Compound 3, half-maximal inhibitory concentration: 1650 nM
For compound 3 the middle estimate is 2.1-fold (0.31 log units) below the measured one; the range from low to high includes it.
By their numbers in this assay, from the lowest: compounds 1 and 2 (each within the scatter of the next); then compound 3.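

Pyridin-4-yl in place of phenyl on a double-bonded chain carbon bound to a double-bonded chain carbon gives a 2.7-fold higher number from compound 1 to compound 3 (0.43 log units; beyond the scatter) in this assay. This modest step shows that the place responds to a change in the ring, which now carries a nitrogen, and that the change goes with weaker inhibition. No measurement shown accounts for the step. The compounds shown leave open how pyridin-3-yl or a phenyl carrying an amine or a carboxylic acid would read at this place. Also open, going by these compounds, is whether the same swap would give a similar step on compound 2 .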